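Amide substituent swap: compound 1 to compound 3

This account rests on a few compounds, and the source may have more. Where it says the series, first, only, none or still open, it means among the compounds named here.

Among the compounds with values here, in an ADME assay on Vero cells (Chlorocebus sabaeus) for cytotoxicity, read by MTT assay (on this read-out lower numbers stand for stronger inhibition and higher numbers for weaker inhibition), compound 1 (`CC(C)NC(=O)c1cc(N(C)Cc2ccc(C(F)(F)F)cc2)ncn1`) gives 217000 nM as the only exact number so far. Compound 2 (`CC(=O)N1CCN(c2ccc(NC(=O)c3cc(N(C)Cc4ccc(C(F)(F)F)nc4)ncn3)cc2)CC1`) reads > 50000 nM in this assay and that value is a limit of the assay, not a number.

Compound 3 (`CN(Cc1ccc(C(F)(F)F)cc1)c1cc(C(=O)Nc2ncn(C)n2)ncn1`) carries 1-methyl-1H-1,2,4-triazol-3-yl in place of isopropyl on an amide-type nitrogen and otherwise keeps the core of compound 1. Within the data shown here, no measured step sizes such a change. The estimated 1.8-fold lower number from compound 1 to compound 3 (0.26 log units; within the scatter) is a modest one toward lower numbers in this assay and lies close to the scatter, and a reading reported only as a limit would be no surprise. For compound 3 the estimated value is 120000 nM with an expected range from 35000 nM to 350000 nM for the measurement still to come.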

Compound 3, half-maximal inhibitory concentration in the Vero assay: 28000 nM
Beside the measured number, compound 3's estimate is 4.3-fold (0.63 log units) above it; measured number outside the range, below it.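

Within the data shown here, in the Vero assay, the amide-type nitrogen proves to be a place where the read-out moves: 1-methyl-1H-1,2,4-triazol-3-yl in place of isopropyl gives a 7.8-fold lower number from compound 1 to compound 3 (0.89 log units; beyond the scatter), the first step to size a change here. In a physicochemical assay for solubility, using the shake flask method, measured as kinetic solubility, with a stated time of 2 h, at pH 7.4 (on this read-out higher numbers stand for higher solubility and lower numbers for lower solubility), compound 1 gives 13000 nM and compound 3 gives 173000 nM. The same change also raises the reading in the physicochemical assay: the measured solubility of compound 1, 13000 nM, and of compound 3, 173000 nM, a 13-fold higher number (1.12 log units; beyond the scatter). This single pair therefore shows both read-outs moving beyond the scatter with one substituent swap on the shared core.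

Among these compounds, with only one step at this place, it stays open whether other substituents on the amide-type nitrogen, such as a longer alkyl chain or a carboxylic acid, would move the two read-outs together or apart. In the Vero assay, compound 2 gives > 50000 nM, which is a limit and not a number, so it cannot size any change.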